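The source may hold more compounds than are shown below. What is called first, only, known or untested is meant among the compounds shown, and "the series" means these compounds.

Working notes on the series, in a physicochemical assay for solubility, with a stated time of 3 days, at pH 7; a lower number here means a less soluble compound, a higher number a more soluble compound: compound 1 `Cc1ccc(CN2CCCCC2CCOc2ccc(-c3nc4cc(C(N)=O)ccc4[nH]3)cc2)cc1` gives 97000 nM, while compound 2 `NC(=O)c1ccc2[nH]c(-c3ccc(OCCC4CCCCN4C(=O)c4ccccc4)cc3)nc2c1` gives 18000 nM, the lower of the two numbers. Compound 3 `CC(=O)N1CCCCC1CCOc1ccc(-c2nc3cc(C(N)=O)ccc3[nH]2)cc1` has methyl in place of phenyl on a carbonyl carbon, benzoyl to acetyl: methyl in place of phenyl on a carbonyl carbon. Going by the values given here, the only measured step, a 5.4-fold lower number from compound 1 to compound 2 (0.73 log units; beyond the scatter), has benzoyl in place of 4-methylbenzyl on an amine nitrogen in a ring. It does not test this change directly, so it offers only loose guidance on size. A modest rise beyond the scatter is expected, a 2.8-fold higher number from compound 2 to compound 3 (0.44 log units; beyond the scatter). The estimate for compound 3 is 50000 nM, with an expected range of 20000 nM to 130000 nM.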

Compound 3, solubility: 193000 nM
Estimate against measurement, compound 3: 3.9-fold (0.59 log units) below; measured number above the stated range.
By their numbers in this assay, from the lowest: compound 2; then compounds 1 and 3 (each within the scatter of the next).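

In this assay, the group on the carbonyl carbon matters more than the earlier pair could show: an 11-fold higher number from compound 2 to compound 3 (1.03 log units; beyond the scatter) comes with methyl in place of phenyl. With a 2.0-fold higher number from compound 1 to compound 3 (0.30 log units; within the scatter) between them, compound 1 and compound 3 are not separated, so a carbonyl on the ring nitrogen does not by itself go with the lower number, which so far belongs to benzoyl in compound 2 alone. No measured evidence bears on the reason for this step. Open, as far as these compounds go, is where a longer chain on the carbonyl carbon, such as propanoyl, would fall, or a carbonyl carrying an amine, such as aminoacetyl.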